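Moving the nitro group: expectation for compound 4

This account rests on a few compounds, and the source may have more. Where it says the series, first, only, none or still open, it means among the compounds named here.

Three compounds on one shared core are measured in a functional assay on the whole organism for inhibition, with Mus musculus as the target, at a dose of 25 mg/kg by the oral route; a lower number here means less inhibition, a higher number more inhibition at the dose given (going by the name of the read-out). Compound 1 `Clc1ccc(N2CCN(CCCOc3ccc4c(c3)CCC4)CC2)cc1` gives 58%; compound 2 `CC(=O)c1ccc(N2CCN(CCCOc3ccc4c(c3)CCC4)CC2)cc1` gives 0%; compound 3 `O=[N+]([O-])c1ccccc1N1CCN(CCCOc2ccc3c(c2)CCC3)CC1` gives 43%. Compound 3 stands second highest of the three: a number 15 percentage points lower from compound 1 to compound 3 (beyond the scatter) and a number 43 percentage points higher from compound 2 to compound 3 (beyond the scatter). Compound 4 `O=[N+]([O-])c1ccc(N2CCN(CCCOc3ccc4c(c3)CCC4)CC2)cc1` is unmeasured and differs from compound 3 by 4-nitrophenyl in place of 2-nitrophenyl on an amine nitrogen in a ring. Within the data shown here, no measured step moves one and the same group to another place on the ring carried by the amine nitrogen in a ring; the steps of a number 58 percentage points lower from compound 1 to compound 2 (beyond the scatter) and a number 15 percentage points lower from compound 1 to compound 3 (beyond the scatter) exchange the group itself, so they leave the direction open. The step of a number 3 percentage points lower from compound 3 to compound 4 (within the scatter) is therefore expected to stay near zero, with wide uncertainty. Compound 4 is estimated at 40%, between 10% and 65%.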

Compound 4, a percentage reported as inhibition, in the whole organism at one dose (the size of the read-out at that dose, not a potency): 26%
The estimate for compound 4 lay 14 percentage points above the measured number; low and high end bracket the measured number.
By their numbers in this assay, from the lowest: compound 2; then compound 4; then compound 3; then compound 1.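

Among these compounds, the step of a number 17 percentage points lower from compound 3 to compound 4 (beyond the scatter) is the first in this assay with the group itself unchanged, so the place of the nitro group on the ring carried by the amine nitrogen counts, with 2-nitrophenyl ahead of 4-nitrophenyl. With a number 32 percentage points lower from compound 1 to compound 4 (beyond the scatter) and a number 26 percentage points higher from compound 2 to compound 4 (beyond the scatter) in hand, nitro ranks between chloro and acetyl on the ring. Nothing measured gives a reason for this order.

On these data alone, whether 2-chlorophenyl or 2-acetylphenyl would follow the nitro pair stays open. So does how an amine or a carboxylic acid on the same ring would compare.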